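The source may hold more compounds than are shown below. What is called first, only, known or untested is meant among the compounds shown, and "the series" means these compounds.

Compound 1 `COc1cc(NCc2ccc(Cl)s2)ccc1-c1cnco1`, compound 2 `COc1cc(/N=C/c2ccc(F)cc2)ccc1-c1cnco1` and compound 3 `CCc1ccc(CNc2ccc(-c3cnco3)c(OC)c2)s1` share one core and were each tested in an ADME assay on Huh-7 cells (Homo sapiens) for cytotoxicity, read by MTT assay, with a stated time of 96 h; on this read-out higher numbers stand for lower toxicity in this test and lower numbers for higher toxicity in this test. In this assay compound 1 gives 43200 nM, and compound 3 gives 39100 nM. Among the compounds with values here, the only measured step between neighbours, a 1.1-fold lower number from compound 1 to compound 3 (0.04 log units; within the scatter), swaps one group on an aromatic carbon and leaves the read-out where it was. Compound 2 stands apart from these two. In this assay compound 2 gives > 100000 nM, which is a limit of the assay rather than a number, as the limit of > 100000 nM in this assay, at which 1 of the 3 values shown sits, records. Compound 2 therefore sits at the upper edge of what the test can report, with the other two compounds below it.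

Compound 4 `COc1cc(/N=C/c2ccncc2)ccc1-c1cnco1` has not yet been measured. It differs from compound 2 in one place: pyridin-4-yl in place of 4-fluorophenyl on a carbon with a double bond to nitrogen. Within the data shown here, no measured step concerns a change of this kind, and the one step that is known was within the scatter and involved a different group at a different place, so it gives no direction to lean on. For this assay compound 4 is expected to give 100000 nM, with a range from 40000 nM to 250000 nM. The step this estimate means, a number no higher from compound 2 to compound 4 (the limit leaves the size open), is expected to stay within the scatter, with a fair chance that compound 4 again returns only a limit.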

Compound 4, half-maximal cytotoxic concentration: > 100000 nM
Compound 4 was reported as a limit; the forecaster's own chance of this, stated with the estimate: 60%; the middle value sits exactly at the limit.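

In this assay compound 4 gives > 100000 nM, which is a limit of the assay and not a number. Compound 2 also sits at a limit, so no step can be read between the two: the limit of > 100000 nM in this assay, at which 2 of the 4 values shown sit.

The compounds shown leave open whether pyridin-4-yl and 4-fluorophenyl give different numbers in this assay at all.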